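A few compounds are considered here, and "the series" means these few. Any claim that something is new, unique, unknown or untested is made for them only; others in the source may bear on it.

Measured so far:
- compound 1, `COc1cc(-c2nnc(SCC(=O)c3ccccc3F)n2N)cc(OC)c1OC`: 43100 nM
- compound 2, `COc1ccc(C(=O)CSc2nnc(-c3cc(OC)c(OC)c(OC)c3)n2N)cc1`: 97900 nM

In a functional assay on PC-3 cells (Homo sapiens) for antiproliferative activity, read by MTT assay, with a stated time of 48 h (on this read-out lower numbers stand for stronger inhibition and higher numbers for weaker inhibition), compound 2 gives 97900 nM, the highest of the two numbers measured; its nearest neighbour, compound 1, gives 43100 nM. Among the compounds with values here, the only step measured so far, a 2.3-fold higher number from compound 1 to compound 2 (0.36 log units; beyond the scatter), swapped one aryl group for another on the carbonyl carbon and moved the number modestly upward. Compound 3, `COc1cc(-c2nnc(SCC(=O)NCc3ccc(C)cc3)n2N)cc(OC)c1OC`, changes the same position again, but more deeply: (4-methylbenzyl)amino in place of 4-methoxyphenyl on a carbonyl carbon. The carbonyl now carries an amino group bearing a 4-methylbenzyl chain, so an amide takes the place of the ketone. Within the data shown here, the single measured step bears on the position but not on this kind of change, so it is only loosely informative. Accordingly, the expectation for compound 3 in this assay is a small downward step, a 1.6-fold lower number from compound 2 to compound 3 (0.21 log units; within the scatter), and compound 3 is estimated at 60000 nM with a range from 20000 nM to 180000 nM.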

Compound 3, half-maximal inhibitory concentration: 92800 nM
Compound 3: the middle estimate sits 1.5-fold (0.19 log units) below what was measured; the measured number falls inside the stated range.
By their numbers in this assay, from the lowest: compound 1; then compounds 3 and 2 (each within the scatter of the next).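

In this assay, the change from a ketone to an amide at this carbonyl carbon gives a 1.1-fold lower number from compound 2 to compound 3 (0.02 log units; within the scatter) and so leaves compound 2 and compound 3 indistinguishable, even though a (4-methylbenzyl)amino group brings a hydrogen-bond donor that 4-methoxyphenyl lacks. The same amide measured against the 2-fluorophenyl ketone gives a 2.2-fold higher number from compound 1 to compound 3 (0.33 log units; beyond the scatter) and leaves compound 1 as the most potent of the three, so this position has so far tolerated a ketone and an amide with only modest differences. No measurement here accounts for these numbers.

Only one amide is shown, so a plain benzylamino group or a 2-fluorobenzylamino group could behave differently. A carboxylic acid or a dimethylamino group on this carbonyl carbon also remains an open case.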